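The source may hold more compounds than are shown below. What is called first, only, known or untested is meant among the compounds shown, and "the series" means these compounds.

Working notes on the series in an assay on HEK293 cells for inhibition of nuclear factor NF-kappa-B complex (Homo sapiens), read by a luciferase reporter, with stated times of 1 h and 3 h; on this read-out higher numbers stand for weaker inhibition and lower numbers for stronger inhibition.

Compound 1 `CC(C)(C)CNC(=O)C[C@H](NC(=O)CCc1ccccc1)C(=O)N[C@@H](CCc1ccccc1)C(=O)NCc1ccccc1` gives 12 nM. Compound 2 `Cc1cc(C(=O)N[C@@H](CC(=O)NCC(C)(C)C)C(=O)N[C@@H](CCc2ccccc2)C(=O)NCc2ccccc2)no1` gives 9 nM. Compound 3 `C[C@H](NC(=O)[C@H](CC(=O)NCC(C)(C)C)NC(=O)CCc1ccccc1)C(=O)NCc1ccccc1Cl` gives 10 nM. The difference between the core of compound 1 and the core of compound 3 is not broken down here; the two numbers they give sit close together, and nothing of order is read into that.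

Compound 1 and compound 2 differ in a single place: 5-methyl-1,2-oxazol-3-yl in place of phenethyl on a carbonyl carbon. The step on this read-out is a 1.3-fold lower number from compound 1 to compound 2 (0.12 log units; within the scatter), so the first occurrence of this change leaves the number essentially where it was.

Compound 4 `Cc1cc(C(=O)N[C@@H](CC(=O)NCC(C)(C)C)C(=O)N[C@@H](C)C(=O)NCc2ccccc2Cl)no1` has not yet been measured. It stands to compound 3 as compound 2 stands to compound 1: 5-methyl-1,2-oxazol-3-yl in place of phenethyl on a carbonyl carbon. The place is the same in both cases, a carbonyl carbon whose other neighbour is an amide-type nitrogen, so this is the same change, occurring twice among the compounds shown.

For compound 4 the step expected is a 1.3-fold lower number from compound 3 to compound 4 (0.10 log units; within the scatter). This expectation rests on the earlier step of a 1.3-fold lower number from compound 1 to compound 2 (0.12 log units; within the scatter), which stayed within the scatter, and on compound 3 giving 10 nM, close to compound 1 with 12 nM, so that the second occurrence starts from much the same number as the first. The number expected for compound 4 is 8 nM, with a range estimated from 4 nM to 16 nM.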

Compound 4, half-maximal inhibitory concentration: 120 nM
For compound 4 the middle estimate is 15-fold (1.18 log units) below the measured one; the measured number lies above the stated range.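

In this assay, placing 5-methyl-1,2-oxazol-3-yl in place of phenethyl on a carbonyl carbon gives a 12-fold higher number from compound 3 to compound 4 (1.08 log units; beyond the scatter), so on the core of compound 3 the change costs a large part of the inhibition rather than leaving the number where it was. For the compounds shown here, the two occurrences of this one change do not agree: the same change on two cores in this assay, a 1.3-fold lower number (0.12 log units; within the scatter) from compound 1 to compound 2 and a 12-fold higher number (1.08 log units; beyond the scatter) from compound 3 to compound 4, 16-fold (1.20 log units) apart, beyond the scatter of two such steps This shows that, in this series, the result of the change on one core cannot simply be carried over to another; it does not show what sets the two cores apart, and with only two pairs it gives no rule for which cores tolerate the change and which do not.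

The compounds shown leave open which part of the difference between the core of compound 1 and the core of compound 3 goes with the gap between the two steps, as the two cores are not broken down into single changes here. They also leave open whether another group on the same carbonyl carbon, such as a cyclohexylethyl chain or a longer phenylpropyl chain, would keep the number of compound 3 or would fall away as compound 4 does.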